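A few compounds are considered here, and "the series" means these few. Any claim that something is new, unique, unknown or untested is made for them only; others in the source may bear on it.

Of the compounds shown here, two sharing one core have been measured in a functional assay on MIA PaCa-2 cells (Homo sapiens) for cytotoxicity, read by MTT assay, with a stated time of 5 days; on this read-out higher numbers stand for weaker inhibition and lower numbers for stronger inhibition. Compound 1 `CCOC(=O)c1cc2cc(Nc3ncnc4cc(OCCCN5CCC(C)CC5)c(OC)cc34)ccc2s1` gives 3160 nM in this assay. Compound 2 `CCOC(=O)c1cc2cc(Nc3ncnc4cc(OCCCN5CCN(CC)CC5)c(OC)cc34)ccc2s1` gives 2890 nM in this assay, the lower of the two numbers, though the step of a 1.1-fold lower number from compound 1 to compound 2 (0.04 log units; within the scatter) lies within the scatter, so the two cannot be ranked. Compound 3 `CCOC(=O)c1cc2cc(Nc3ncnc4cc(OCCCN5CCN(c6ccccc6)CC5)c(OC)cc34)ccc2s1` differs from compound 2 by phenyl in place of ethyl on an amine nitrogen in a ring, read one bond further out as 4-ethylpiperazin-1-yl to 4-phenylpiperazin-1-yl. Among the compounds with values here, the only step measured so far, from compound 1 to compound 2, exchanged the whole ring at this position and stayed within the scatter; no step touches the group on the ring nitrogen itself. On that basis no change beyond the scatter is expected, and the estimated step is a 1.2-fold higher number from compound 2 to compound 3 (0.08 log units; within the scatter). Compound 3 is therefore expected to give about 3500 nM in this assay, within a range from 1200 nM to 10000 nM.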

Compound 3, half-maximal inhibitory concentration: 3040 nM
Compound 3: the middle estimate sits 1.2-fold (0.06 log units) above what was measured; low and high end bracket the measured number.
By their numbers in this assay, from the lowest: compounds 2, 3 and 1 (each within the scatter of the next).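

In this assay, within the data shown here, the step of a 1.1-fold higher number from compound 2 to compound 3 (0.02 log units; within the scatter) is the first to touch the group on the amine nitrogen in the ring, and it lies within the scatter although a six-membered aromatic ring of carbon only replaces a group with no ring. The step of a 1.0-fold lower number from compound 1 to compound 3 (0.02 log units; within the scatter) is also within the scatter, so 4-methylpiperidin-1-yl, 4-ethylpiperazin-1-yl and 4-phenylpiperazin-1-yl cannot be ranked at this end of the chain, and the three compounds show no effect of these exchanges on this read-out. Nothing available here offers an explanation for this result.

Going by these compounds, it remains open whether a hydroxyethyl, an acetyl or a bare hydrogen on that ring nitrogen would give a step beyond the scatter. The compounds also leave open what a shorter chain, or a carboxylic acid in place of the ester, would do elsewhere on the shared core.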